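The source may report more compounds than this note shows. Statements on the series, on what has been measured and on what is new or still open speak of the compounds shown alone.

Among the measured compounds shown here, compound 1 `Cc1cc2c(cc1Cl)NC(=O)C2(NC(=O)CN1CCN(C)CC1)c1cccc(Cl)c1` is the one member of this small set with a numerical result: in an in vitro functional assay on CHO-CREluc cells for antagonist activity at growth hormone secretagogue receptor type 1 (Homo sapiens), read by a luciferase reporter, with a stated time of 4 h (a higher number here means a weaker inhibitor, a lower number a stronger inhibitor), compound 1 gives 1180 nM. The two companions give only limits. Compound 2 `CN(C)CCN(C)CC(=O)NC1(c2ccc(Cl)cc2)C(=O)Nc2cc(Cl)c(Cl)cc21` is reported in this assay at > 10000 nM, which is a limit of the assay and not a measured number. Compound 3 `Cc1cc2c(cc1Cl)NC(=O)C2(NC(=O)CN1CCNCC1)c1ccc(Cl)cc1` likewise stands in this assay at > 10000 nM, again a limit rather than a number. So compound 1 is the sole point of reference here, and the others tell only that they fall beyond (the limit of > 10000 nM in this assay, at which 2 of the 3 values shown sit).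

Compound 4 `Cc1cc2c(cc1Cl)NC(=O)C2(NC(=O)CN1CCN(C)CC1)c1ccccc1Cl` keeps the core of compound 1 and changes one thing: 2-chlorophenyl in place of 3-chlorophenyl on a saturated ring carbon. No pair of measured compounds differs in this way, so the data give no measured step of this kind to lean on, and no cause can be assigned to it.

With that absence, the expectation for compound 4 is a modest loss, a step in this assay of a 2.1-fold higher number from compound 1 to compound 4 (0.33 log units; beyond the scatter), but the uncertainty is wide enough that the result could also sit within the usual scatter of compound 1. Compound 4 is therefore estimated at 2500 nM in this assay, within a range from 600 nM to 10000 nM, with a real chance that only a limit is reported.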

Compound 4, half-maximal inhibitory concentration: > 10000 nM
Compound 4: no number, only a limit; the forecaster's own chance of this, stated with the estimate: 30%; middle value at least 4.0-fold (0.60 log units) away from the limit.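

Replacing 3-chlorophenyl with 2-chlorophenyl on a saturated ring carbon of the core of compound 1 gives, in this assay, an at least 8.4-fold higher number from compound 1 to compound 4 (0.92 log units; beyond the scatter). Among the compounds shown here, this is the first single-change comparison in the set, and it shows that with the same atoms, joining the chlorine differently on this phenyl group is enough to set the one compound with a numerical reading apart from a compound without one. The reading for compound 4, > 10000 nM, is a limit of the assay and not a number, so the true size of the step stays unknown, and compound 4 joins the other compounds at that limit: the limit of > 10000 nM in this assay, at which 3 of the 4 values shown sit.

The compounds shown do not tell how far compound 4 lies beyond that limit, nor why this change has the effect it has. They also leave open how an unsubstituted phenyl or a 3-fluorophenyl at this same place, on the core of compound 1, would read in this assay, and so whether the 3-chloro group itself matters or only the absence of a 2-chloro group.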